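Lengthening the amine chain: compound 3 to compound 4

The source may report more compounds than this note shows. Statements on the series, on what has been measured and on what is new or still open speak of the compounds shown alone.

Values in a functional assay on HeLa cells (Homo sapiens) for antiproliferative activity, read by MTT assay, with a stated time of 48 h; a higher number here means a weaker inhibitor, a lower number a stronger inhibitor:
- compound 1 `CN(C)CCCCn1c(N)c(-c2nc3ccccc3s2)c2nc(C#N)c(C#N)nc21`: 18700 nM
- compound 2 `CN(C)CCn1c(N)c(-c2nc3ccccc3n2C)c2nc(C#N)c(C#N)nc21`: > 50000 nM (a limit)
- compound 3 `CN(C)CCCn1c(N)c(-c2nc3ccccc3n2C)c2nc(C#N)c(C#N)nc21`: 4320 nM
- compound 4 `CN(C)CCCCn1c(N)c(-c2nc3ccccc3n2C)c2nc(C#N)c(C#N)nc21`: not yet measured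

Of the two exact values, compound 3 at 4320 nM stands lowest, and compound 1 lies higher by a margin beyond the scatter. The next change places (dimethylamino)methyl in place of dimethylamino on a saturated chain carbon, three bonds along the chain from an aromatic nitrogen. This reads as 3-(dimethylamino)propyl to 4-(dimethylamino)butyl.

Going by the values given here, the one measured step of this kind, two bonds along the chain, is large: an at least 11-fold lower number from compound 2 to compound 3 (1.06 log units; beyond the scatter). It starts from a limit. The 4-(dimethylamino)butyl chain also occurs in compound 1 at 18700 nM, but with a different group on the shared core. A single step sets no trend, so in this assay only a small further lowering is expected, probably within the scatter. The expected change is a 1.4-fold lower number from compound 3 to compound 4 (0.16 log units; within the scatter). For compound 4 the estimated value is 3000 nM, with an expected range of 800 nM to 12000 nM.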

Compound 4, half-maximal inhibitory concentration: 460 nM
Estimate against measurement, compound 4: 6.5-fold (0.81 log units) above, and the stated range ends above it.
By their numbers in this assay, from the lowest: compound 4; then compound 3; then compound 1. At a limit, above all of these: compound 2.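

Lengthening 3-(dimethylamino)propyl to 4-(dimethylamino)butyl gives a further fall in this assay, a 9.4-fold lower number from compound 3 to compound 4 (0.97 log units; beyond the scatter), and the lowering seen at the shorter chain carries on to the next chain length, with no levelling off among compounds 2, 3 and 4. The whole span of chains shown reads an at least 100-fold lower number from compound 2 to compound 4 (2.03 log units; beyond the scatter), a step that starts from a limit and not from a number: the limit of > 50000 nM in this assay, at which 1 of the 4 values shown sits.

With the 4-(dimethylamino)butyl chain held fixed, the group on the shared core also proves decisive, with 1-methyl-1H-benzimidazol-2-yl in place of 1,3-benzothiazol-2-yl giving a 41-fold lower number from compound 1 to compound 4 (1.61 log units; beyond the scatter).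

Open, on these data alone, is whether a longer chain than 4-(dimethylamino)butyl lowers the number further or reverses the run, and whether a cyclic amine such as pyrrolidine or morpholine can stand in for dimethylamino. Also open is whether the chain-length run holds with 1,3-benzothiazol-2-yl on the core, where only compound 1 is shown.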